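The compounds below may be only part of what the source reports. "The series", "measured", "known", "first", "only" and "open" are said of these compounds alone.

In a functional assay on DU-145 cells (Homo sapiens) for inhibition, read by trypan blue exclusion, with a stated time of 96 h (on this read-out lower numbers stand for stronger inhibition of growth and higher numbers for weaker inhibition of growth), compound 1 `Cc1ccc(S/C(=C/c2ccc(N(C)C)cc2)C(=O)c2ccc(Cl)cc2)cc1` gives > 100000 nM, which is a limit and not a number. For the measured compounds named here, compound 2 `Cc1ccc(S/C(=C/c2ccc[nH]2)C(=O)c2ccc(Cl)cc2)cc1` gives 10000 nM, the only actual number so far. Compound 3 `Cc1ccc(S/C(=C/c2ccc(Cl)cc2Cl)C(=O)c2ccc(Cl)cc2)cc1` differs from compound 2 at a single place: 2,4-dichlorophenyl in place of 1H-pyrrol-2-yl on a double-bonded chain carbon bound to a double-bonded chain carbon. Going by the values given here, one measured step bears on this place. Compound 3 again carries a substituted phenyl group there, so part of the step of an at least 10-fold lower number from compound 1 to compound 2 (1.00 log units; beyond the scatter) is expected to be undone. The expected change in this assay is therefore modest and towards weaker inhibition, an estimated 2.0-fold higher number from compound 2 to compound 3 (0.30 log units; within the scatter). For compound 3 the estimate is 20000 nM, with an expected range of 4000 nM to 100000 nM.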

Compound 3, concentration for 50% growth inhibition: 10000 nM
Beside the measured number, compound 3's estimate is 2.0-fold (0.30 log units) above it; the measured number falls inside the stated range.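

In this assay, the change to 2,4-dichlorophenyl gives no change at the digits printed from compound 2 to compound 3 (within the scatter), so the hydrogen-bond donor of 1H-pyrrol-2-yl is not needed at this place to keep that number, and a six-membered aromatic ring of carbon only is accepted there. The second step, an at least 10-fold lower number from compound 1 to compound 3 (1.00 log units; beyond the scatter), shows that a phenyl ring as such does not carry the weak result, which goes with 4-(dimethylamino)phenyl alone among these compounds. That step rests on a limit and not on a number: the limit of > 100000 nM in this assay, at which 1 of the 3 values shown sits.

From the compounds shown here alone, it remains open whether plain phenyl or a single chlorine would serve as well as 2,4-dichlorophenyl. A carboxylic acid or a primary amine on the ring at this place is also untested here.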